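Shifting the aryl group on the central carbon

This account rests on a few compounds, and the source may have more. Where it says the series, first, only, none or still open, it means among the compounds named here.

Among the measured compounds shown here, compound 2 `Cc1ccnc(NC(c2ccc(F)cc2)c2ccc3cccnc3c2O)c1` gives 140 nM in an assay for inhibition of protein disulfide-isomerase (Homo sapiens), with a stated time of 1 h (a higher number here means a weaker inhibitor, a lower number a stronger inhibitor), the lowest of the two numbers measured so far; its nearest neighbour is compound 1 `Cc1ccnc(NC(c2ccc(C(F)(F)F)cc2)c2ccc3cccnc3c2O)c1`, which gives 26500 nM. That pair shows a 190-fold lower number from compound 1 to compound 2 (2.28 log units; beyond the scatter), a change confined to the same aryl ring. Compound 3 `Cc1ccnc(NC(c2ccc3cccnc3c2O)c2c(F)cccc2Cl)c1` differs from compound 2 by 2-chloro-6-fluorophenyl in place of 4-fluorophenyl on a saturated chain carbon bound to an aromatic carbon and a nitrogen on an aromatic ring. For the measured compounds named here, no measured step tests this exact exchange; the only step shows that this ring moves the number strongly. Compound 3 is therefore expected to shift by a 2.1-fold higher number from compound 2 to compound 3 (0.33 log units; beyond the scatter), with wide uncertainty, giving an estimated 300 nM (range 60 nM to 2000 nM).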

Compound 3, half-maximal inhibitory concentration: > 40000 nM
Compound 3 ended at the assay's limit; the forecaster's own chance of this, stated with the estimate: 5%; at least 130-fold (2.12 log units) between middle value and limit.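

Putting 2-chloro-6-fluorophenyl in place of 4-fluorophenyl on this saturated chain carbon gives an at least 280-fold higher number from compound 2 to compound 3 (2.45 log units; beyond the scatter), so a second change of this aryl ring also costs heavily, and of the three rings shown only 4-fluorophenyl holds the number low. For compound 3, > 40000 nM is a limit of this assay, not a number. Putting 2-chloro-6-fluorophenyl in place of 4-(trifluoromethyl)phenyl on the same carbon gives an at least 1.5-fold higher number from compound 1 to compound 3 (0.17 log units; that floor lies within the scatter), so this step fixes no order between these two rings. The compounds shown leave open whether the chlorine alone accounts for the rise, and how a plain phenyl or a 4-methoxyphenyl ring would read on this carbon.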